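Trimethoxyphenyl series: nitro for trifluoromethyl on the aroyl ring

This account rests on a few compounds, and the source may have more. Where it says the series, first, only, none or still open, it means among the compounds named here.

Measured so far:
compound 1, `COc1cc(-c2nnc3n2NC(c2cccs2)C(C(=O)c2ccc(Cl)cc2)S3)cc(OC)c1OC`, 32500 nM
compound 2, `COc1cc(-c2nnc3n2NC(c2ccco2)C(C(=O)c2ccc(C(F)(F)F)cc2)S3)cc(OC)c1OC`, 77500 nM

Both values come from a functional assay on PC-3 cells (Homo sapiens) for cytotoxicity, read by MTT assay, with a stated time of 48 h; a lower number here means a stronger inhibitor, a higher number a weaker inhibitor. Among the compounds with values here, compound 2 gives the higher of the two numbers, and its gap to compound 1 lies beyond the scatter of repeated runs; with only two compounds measured, nothing more can be said about a trend.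

Compound 3, `COc1cc(-c2nnc3n2NC(c2ccco2)C(C(=O)c2ccc([N+](=O)[O-])cc2)S3)cc(OC)c1OC`, is not yet measured. It differs from compound 2 in one place: nitro in place of trifluoromethyl on an aromatic carbon. Within the data shown here, no pair differing in just this way has been measured, so the size of the step has no precedent.

Among the measured compounds shown here, with no comparable step available, the step from compound 2 to compound 3 in this assay is expected to stay roughly within the scatter, estimated as a 1.3-fold lower number from compound 2 to compound 3 (0.11 log units; within the scatter). For compound 3 the value is estimated at 60000 nM, with a range from 25000 nM to 150000 nM.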

Compound 3, half-maximal inhibitory concentration: 27900 nM
The estimate for compound 3 lay 2.2-fold (0.33 log units) above the measured number; low and high end bracket the measured number.
By their numbers in this assay, from the lowest: compounds 3 and 1 (each within the scatter of the next); then compound 2.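

In this assay, within the data shown here, the change from 4-(trifluoromethyl)phenyl to 4-nitrophenyl gives the first single-place step (a 2.8-fold lower number from compound 2 to compound 3 (0.44 log units; beyond the scatter)), and it lies beyond the scatter. This aromatic carbon is therefore a place where swapping one group for another moves the number, at least with the rest of compound 2 held constant. No measurement at hand explains the step, and the swap's other differences, in heavy atoms and hydrogen-bond acceptors, cannot be separated from it here.

Compound 1 carries a chlorine on the corresponding ring but also differs elsewhere, so it gives no reading on this position alone. Still open, on these data alone, are how an amine or a carboxylic acid on the same aromatic carbon would read, and whether the step carries over to a different core substituent.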